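Aryl Groups on the Ring Amine and Electroshock Dose

The compounds below may be only part of what the source reports. "The series", "measured", "known", "first", "only" and "open" are said of these compounds alone.

Measured compounds:
compound 1 `CC1(c2ccccc2)CC(=O)N(CC(=O)N2CCN(c3ccccc3F)CC2)C1=O` gives 100 mg/kg
compound 2 `CC1(c2ccccc2)CC(=O)N(CC(=O)N2CCN(c3cccc(Cl)c3)CC2)C1=O` gives 300 mg/kg

Among the compounds with values here, in a functional assay on the whole organism (strain CD-1) with Mus musculus as the target, in the maximal electroshock model, with a stated time of 0.5 h (a higher number here means that more compound is needed for the effect, a lower number that less compound is needed), compound 1 gives 100 mg/kg, the lowest of the two numbers so far; the nearest is compound 2, with a 3.0-fold higher number from compound 1 to compound 2 (0.48 log units; beyond the scatter). The unmeasured compound 3 `CC1(c2ccccc2)CC(=O)N(CC(=O)N2CCN(c3ccc(Cl)c(Cl)c3)CC2)C1=O` differs from compound 1 in one place: 3,4-dichlorophenyl in place of 2-fluorophenyl on an amine nitrogen in a ring. Within the data shown here, only one measured step bears on this change, a 3.0-fold higher number from compound 1 to compound 2 (0.48 log units; beyond the scatter), where a chlorine-bearing aryl group replaced the 2-fluorophenyl on the same ring nitrogen and the number rose modestly, beyond the scatter. Compound 3 carries 3,4-dichlorophenyl, again a chlorine-bearing aryl group in place of 2-fluorophenyl, so a step of similar direction is expected in this assay, namely a 3.0-fold higher number from compound 1 to compound 3 (0.48 log units; beyond the scatter). Compound 3 is therefore estimated at 300 mg/kg, with a range from 100 mg/kg to 600 mg/kg.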

Compound 3, minimum effective dose: "not active" (no number reported)
Nothing numeric was reported for compound 3, and the estimate cannot be compared.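

Within the data shown here, compound 3 is reported as not active in this assay without a number, so no step from compound 1 to compound 3 can be read. Nothing shown accounts for this result. The compounds shown leave open how far 3,4-dichlorophenyl separates from 2-fluorophenyl on this ring nitrogen.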